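The compounds below may be only part of what the source reports. "The series", "measured", "known", "first", "only" and "open" are said of these compounds alone.

Measured compounds:
compound 1 `COc1ccc(OC)c(/C=C/c2nnc(Nc3ccc(Cl)cc3)o2)c1`: 7600 nM
compound 2 `COc1ccc(OC)c(/C=C/C(=O)N/N=C/c2ccc(Cl)cc2)c1`: 718 nM

In a functional assay on SF-268 cells (Homo sapiens) for antiproliferative activity, read by sulforhodamine B assay, with a stated time of 48 h (a lower number here means a stronger inhibitor of growth, a higher number a weaker inhibitor of growth), compound 2 gives the lower of the two numbers; compound 1 sits well above it, beyond the scatter, so compound 2 is the stronger growth inhibitor of the pair. Compound 3 `COc1ccc(OC)c(/C=C/C(=O)N/N=C/c2ccccc2)c1` is not yet measured. It differs from compound 2 by hydrogen in place of chloro on an aromatic carbon. For the measured compounds named here, no step between measured compounds covers this change, so the expectation rests on the change alone. In this assay a modest loss of potency is expected, a 2.1-fold higher number from compound 2 to compound 3 (0.32 log units; beyond the scatter), only slightly beyond the scatter. Compound 3 is estimated at 1500 nM, within 500 nM to 5000 nM.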

Compound 3, concentration for 50% growth inhibition: 7560 nM
Beside the measured number, compound 3's estimate is 5.0-fold (0.70 log units) below it; the whole stated range lies below it.
By their numbers in this assay, from the lowest: compound 2; then compounds 3 and 1 (each within the scatter of the next).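

In this assay, for the compounds shown here, the chloro group is the only difference within this pair, and the change to 4-chlorophenyl to phenyl is not neutral: hydrogen in its place gives an 11-fold higher number from compound 2 to compound 3 (1.02 log units; beyond the scatter). Going by these compounds alone, this is the first one-place comparison, and it marks the aromatic carbon para to a large group as sensitive to substitution. Nothing at hand bears on the reason for this step.

On these data alone, whether a fluoro, methyl, methoxy or amine group at this position would retain the value of compound 2 stays open. So does whether the same step holds on the core of compound 1, which has no phenyl partner among the compounds shown.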